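The source may report more compounds than this note shows. Statements on the series, on what has been measured and on what is new or still open speak of the compounds shown alone.

Measured so far in a functional assay on MCF7 cells (Homo sapiens) for cytotoxicity, read by MTT assay, with a stated time of 96 h; a lower number here means a stronger inhibitor, a higher number a weaker inhibitor:

- compound 1 `COc1cc(C(=O)c2cn(-c3ccccc3)cc2-c2cccc(Cl)c2)cc(OC)c1OC` gives 540 nM
- compound 2 `COc1cc(C(=O)c2cn(-c3ccccc3)cc2-c2ccccc2[N+](=O)[O-])cc(OC)c1OC` gives 49 nM
- compound 3 `COc1cc(C(=O)c2cn(-c3ccccc3)cc2-c2cc(F)ccc2F)cc(OC)c1OC` gives 230 nM

Compound 3 sits in the middle of these three values, with compound 2 lower and compound 1 higher. Compound 4 `COc1cc(C(=O)c2cn(-c3ccccc3)cc2-c2c(F)cc(F)cc2F)cc(OC)c1OC` carries 2,4,6-trifluorophenyl in place of 2,5-difluorophenyl on an aromatic carbon. All three measured steps are changes at this same place. The largest, an 11-fold lower number from compound 1 to compound 2 (1.04 log units; beyond the scatter), shows that the number can move far with the group there. The other two are modest: a 2.3-fold lower number from compound 1 to compound 3 (0.37 log units; beyond the scatter) and a 4.7-fold higher number from compound 2 to compound 3 (0.67 log units; beyond the scatter). Among the measured compounds shown here, no measured step changes the fluorine count alone, so the direction is poorly fixed. The exchange swaps one fluorinated phenyl for another, so a large step is not expected, and a step within the scatter in this assay is the expectation, leaning slightly lower. The expected step is a 1.4-fold lower number from compound 3 to compound 4 (0.13 log units; within the scatter). For compound 4 the estimate is 170 nM, with an expected range of 60 nM to 480 nM.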

Compound 4, half-maximal inhibitory concentration: 180 nM
Estimate against measurement, compound 4: 1.1-fold (0.02 log units) below, within the range that was stated.
By their numbers in this assay, from the lowest: compound 2; then compounds 4 and 3 (each within the scatter of the next); then compound 1.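

Notes on the position on the five-membered aromatic ring: in this assay the exchange of 2,5-difluorophenyl for 2,4,6-trifluorophenyl gives a 1.3-fold lower number from compound 3 to compound 4 (0.11 log units; within the scatter) and so separates the two fluorinated phenyl groups by no more than the scatter. The new member also falls in the same interval as compound 3, with a 3.7-fold higher number from compound 2 to compound 4 (0.57 log units; beyond the scatter) on one side and a 3.0-fold lower number from compound 1 to compound 4 (0.48 log units; beyond the scatter) on the other, so 2-nitrophenyl still gives the lowest number of the series and 3-chlorophenyl the highest. No measurement at hand accounts for these differences.

From the compounds shown here alone, whether the low number of compound 2 is specific to the nitro group remains open, and a 2-aminophenyl or 2-methoxyphenyl group at this position would test that. Where the unsubstituted phenyl group falls relative to these four compounds also remains open.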